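Estimating cytotoxicity for a methoxy analogue of compound 1

A few compounds are considered here, and "the series" means these few. Any claim that something is new, unique, unknown or untested is made for them only; others in the source may bear on it.

Results in a functional assay on HEY cells (Homo sapiens) for cytotoxicity, read by MTT assay, with a stated time of 72 h; on this read-out higher numbers stand for weaker inhibition and lower numbers for stronger inhibition:
Compound 1 `N[C@H]1CC[C@H](Nc2c(C(=O)NCc3ccc(F)cc3)nc(Br)c3cccnc23)CC1`: "not determined" (no result reported)
Compound 2 `N[C@H]1CC[C@H](NC(=O)c2nc(Br)c3cccnc3c2NCc2ccc(F)cc2)CC1`: 7100 nM

Compound 1 cannot be placed on this scale, since the entry for compound 1 reads "not determined" (no result reported) and gives no single number. Going by the values given here, the only measured number in this small set belongs to compound 2, at 7100 nM.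

The next compound to be tested is compound 3 `COC(=O)c1nc(Br)c2cccnc2c1N[C@H]1CC[C@H](N)CC1`. Its structural change from compound 1 is methoxy in place of (4-fluorobenzyl)amino on a carbonyl carbon. In words, methoxy takes the place of (4-fluorobenzyl)amino on a carbonyl carbon.

A step is normally judged from a measured starting point, and compound 1 does not provide one. No size or direction of step from compound 1 can therefore be expected with any confidence. The best available anchor is compound 2 at 7100 nM, and compound 3 is expected to differ from it by no more than the scatter of this assay. With a single number to go on, the expected range has to stay wide.

For compound 3 the estimated value is 8000 nM, with an expected range of 2000 nM to 30000 nM.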

Compound 3, half-maximal inhibitory concentration: > 20000 nM
Compound 3 was reported as a limit; the forecaster's own chance of this, stated with the estimate: 20%; middle value at least 2.5-fold (0.39 log units) from the limit.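

In this assay, going by these compounds alone, compound 1 has no number to start from, so no step to compound 3 can be read. Compound 3 stands only as a limit of > 20000 nM and not as a number. The compounds shown leave open how far replacing (4-fluorobenzyl)amino with methoxy on a carbonyl carbon shifts cytotoxicity.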